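The source may report more compounds than this note shows. Statements on the series, on what has been measured and on what is new or still open speak of the compounds shown alone.

In a functional assay on PC-3 cells (Homo sapiens) for inhibition, read by MTT assay, with a stated time of 48 h (on this read-out higher numbers stand for weaker inhibition and lower numbers for stronger inhibition), three compounds with the same core differ only in the group on the outer aromatic ring. Compound 1 `Cc1ccc(/C=C2\SC(=O)N(CCNC(=O)Nc3c(C)n(C)n(-c4ccccc4)c3=O)C2=O)cc1`, with methyl, gives 58700 nM. Compound 2 `COc1ccc(/C=C2\SC(=O)N(CCNC(=O)Nc3c(C)n(C)n(-c4ccccc4)c3=O)C2=O)cc1`, with methoxy, gives 13900 nM. Compound 3 `Cc1c(NC(=O)NCCN2C(=O)S/C(=C\c3ccc([N+](=O)[O-])cc3)C2=O)c(=O)n(-c2ccccc2)n1C`, with nitro, gives 69300 nM, which sits level with compound 1, as a 1.2-fold higher number from compound 1 to compound 3 (0.07 log units; within the scatter) shows. Compound 2 stands apart, with a 5.0-fold higher number from compound 2 to compound 3 (0.70 log units; beyond the scatter).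

Compound 4 `COc1cc(/C=C2\SC(=O)N(CCNC(=O)Nc3c(C)n(C)n(-c4ccccc4)c3=O)C2=O)cc(OC)c1OC` has not yet been measured. It differs from compound 3 in one place: 3,4,5-trimethoxyphenyl in place of 4-nitrophenyl on a double-bonded chain carbon bound to a double-bonded ring carbon. In words, 3,4,5-trimethoxyphenyl replaces 4-nitrophenyl on a double-bonded chain carbon bound to a double-bonded ring carbon.

The nearest evidence is the methoxy-bearing compound 2, reached by a modest step from methyl, a 4.2-fold lower number from compound 1 to compound 2 (0.63 log units; beyond the scatter). The step to nitro is of similar size in the opposite direction. Among the measured compounds shown here, no measured compound carries the full trimethoxyphenyl group, so the range must stay wide.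

A modest move towards stronger inhibition is expected, a 4.3-fold lower number from compound 3 to compound 4 (0.64 log units; beyond the scatter). The estimated value for compound 4 is 16000 nM, within an expected range of 5000 nM to 50000 nM.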

Compound 4, half-maximal inhibitory concentration: 35400 nM
Compound 4: the middle estimate sits 2.2-fold (0.34 log units) below what was measured; the range from low to high includes it.
By their numbers in this assay, from the lowest: compound 2; then compounds 4, 1 and 3 (each within the scatter of the next).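

In this assay, replacing 4-methoxyphenyl with 3,4,5-trimethoxyphenyl gives a 2.5-fold higher number from compound 2 to compound 4 (0.41 log units; beyond the scatter), so at this position, more methoxy groups do not extend the advantage seen with the single one. The trimethoxy compound also cannot be separated from the nitro or methyl compounds, with a 2.0-fold lower number from compound 3 to compound 4 (0.29 log units; within the scatter) and a 1.7-fold lower number from compound 1 to compound 4 (0.22 log units; within the scatter), which leaves compound 2 the strongest of the four. No measurement here explains why one methoxy group and three give different results.

As far as these compounds go, it remains open whether a 4-hydroxyphenyl or 4-dimethylaminophenyl group on the same double-bonded chain carbon would match compound 2. It is also unclear whether a phenyl ring with two methoxy groups would fall nearer compound 2 or compound 4.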